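Amide nitrogen substituent swap in a phenoxyacetamide series

The source may report more compounds than this note shows. Statements on the series, on what has been measured and on what is new or still open speak of the compounds shown alone.

Among the measured compounds shown here, compound 2 `Cc1ccc(OCC(=O)N(Cc2cccs2)C2CCCCC2)cc1` carries the highest number of the three measured so far in an assay on HEK293 cells for agonist activity at transient receptor potential cation channel subfamily M member 8 (Homo sapiens), read by fluorescence and calcium flux, with a stated time of 15 min (a lower number here means that less compound is needed, a higher number that more compound is needed for the effect), giving 40000 nM. Compound 1 `CCN(Cc1cccnc1)C(=O)COc1ccc(C)cc1` gives 15400 nM in this assay, a lower number than compound 2 by a margin beyond the scatter. Compound 3 `Cc1ccc2oc(C(=O)N(Cc3cccs3)c3ccn[nH]3)cc2c1`, built on a different core, gives 40 nM in this assay, by far the lowest number of the set.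

The next compound is compound 4 `Cc1ccc(OCC(=O)N(Cc2cccs2)c2ccncc2)cc1`, which differs from compound 2 in one place: pyridin-4-yl in place of cyclohexyl on an amide-type nitrogen. Among the measured compounds no single-point step exists that would calibrate this particular change, so the step is judged from the spread of the set: compound 2 sits at the top, compound 1 somewhat lower, and compound 3 far lower on a different core. Because compound 2 gives 40000 nM, there is room for the number to fall. Compound 4 is expected to give 10000 nM in this assay, with a range from 2500 nM to 40000 nM. The expected step of a 4.0-fold lower number from compound 2 to compound 4 (0.60 log units; beyond the scatter) is a moderate drop, probably beyond the scatter, yet leaving compound 4 well above compound 3; a result within the scatter of compound 2 remains plausible.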

Compound 4, half-maximal effective concentration: 52 nM
Compound 4: middle estimate off by 190-fold (2.28 log units), on the high side; the whole stated range lies above it.
By their numbers in this assay, from the lowest: compounds 3 and 4 (each within the scatter of the next); then compound 1; then compound 2.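

In this assay, the amide-type nitrogen whose other neighbours are the carbonyl carbon and a saturated chain carbon proves highly sensitive to this swap: pyridin-4-yl in place of cyclohexyl gives a 770-fold lower number from compound 2 to compound 4 (2.89 log units; beyond the scatter) on an otherwise unchanged structure. The leaving and entering groups each have 6 heavy atoms, so the step occurs with heavy-atom count held constant, while a non-aromatic carbon ring gives way to an aromatic ring with 1 hetero atom and 1 hydrogen-bond acceptor. No supporting data are available to explain the size of this step.

Phenyl on the same nitrogen would separate the contribution of the aromatic ring from that of the ring nitrogen, while piperidinyl would keep a ring nitrogen in a non-aromatic ring. On these data alone, whether either group follows compound 4 or compound 2 remains open, as does whether the step depends on the ring nitrogen at all.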